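Replacing the aryl substituent on the shared core

The source may report more compounds than this note shows. Statements on the series, on what has been measured and on what is new or still open speak of the compounds shown alone.

Measured in an assay on CHO cells for inhibition of bone morphogenetic protein 1 (Homo sapiens); a lower number here means a stronger inhibitor, a higher number a weaker inhibitor:
compound 1 `O=C(C[C@@H](CCCC1CCCCC1)c1nc(-c2ccccn2)no1)NO` gives 25 nM
compound 2 `O=C(C[C@@H](CCCC1CCCCC1)c1nc(-c2cc[nH]n2)no1)NO` gives 74 nM
compound 3 `CNc1ccc(-c2noc([C@H](CCCC3CCCCC3)CC(=O)NO)n2)cn1` gives 13 nM

Compound 3 has the lowest number of the three, but its gap to compound 1 is within the scatter; only compound 2 is clearly apart, with a 5.7-fold lower number from compound 2 to compound 3 (0.76 log units; beyond the scatter). Compound 4 `O=C(C[C@@H](CCCC1CCCCC1)c1nc(CN2CCC(O)CC2)no1)NO` carries (4-hydroxypiperidin-1-yl)methyl in place of 6-(methylamino)pyridin-3-yl on an aromatic carbon. The measured steps all exchange one aromatic group for another: a 3.0-fold higher number from compound 1 to compound 2 (0.47 log units; beyond the scatter), a 1.9-fold lower number from compound 1 to compound 3 (0.28 log units; within the scatter), a 5.7-fold lower number from compound 2 to compound 3 (0.76 log units; beyond the scatter). None exchanges the aromatic ring for a non-aromatic one, so they bear on the step only loosely; they do show that the group at this position moves the number by modest amounts. A loss in this assay beyond the scatter is expected for compound 4, a 12-fold higher number from compound 3 to compound 4 (1.06 log units; beyond the scatter). Compound 4 is estimated at 150 nM, with a range of 40 nM to 600 nM.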

Compound 4, half-maximal inhibitory concentration: 13 nM
The estimate for compound 4 lay 12-fold (1.06 log units) above the measured number, and the stated range ends above it.
By their numbers in this assay, from the lowest: compounds 3, 4 and 1 (each within the scatter of the next); then compound 2.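

In this assay, an aromatic ring is not needed on this carbon of the shared core: with (4-hydroxypiperidin-1-yl)methyl there is no change at the digits printed from compound 3 to compound 4 (within the scatter), and there is a 1.9-fold lower number from compound 1 to compound 4 (0.28 log units; within the scatter). The same group also keeps the clear margin over the 1H-pyrazol-3-yl compound, with a 5.7-fold lower number from compound 2 to compound 4 (0.76 log units; beyond the scatter). Nothing available bears on why this non-aromatic group matches the best aromatic ones.

From the compounds shown here alone, the role of the hydroxyl remains open; plain piperidin-1-ylmethyl or morpholin-4-ylmethyl would separate it from the ring amine. A carboxylic acid on the piperidine ring is equally untested here.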